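The source may hold more compounds than are shown below. What is called first, only, known or untested is meant among the compounds shown, and "the series" means these compounds.

The compounds measured so far:

compound 1, `CC(C(=O)NCc1ccc(C(F)(F)F)nc1NC1CCCCC1)c1ccc(NS(C)(=O)=O)c(F)c1`: 20.4 nM
compound 2, `CCCCN(C)c1nc(C(F)(F)F)ccc1CNC(=O)C(C)c1ccc(NS(C)(=O)=O)c(F)c1`: 0.8 nM
compound 3, `CC(C(=O)NCc1ccc(C(F)(F)F)nc1N1CC=CCC1)c1ccc(NS(C)(=O)=O)c(F)c1`: 0.3 nM

In a functional assay on CHO-K1 cells for antagonist activity at transient receptor potential cation channel subfamily V member 1 (Homo sapiens), read by FLIPR (a higher number here means a weaker inhibitor, a lower number a stronger inhibitor), compound 3 stands lowest of the three. Its nearest neighbour is compound 2, and the gap between them is a 2.7-fold lower number from compound 2 to compound 3 (0.43 log units; beyond the scatter), a modest step beyond the scatter. The furthest is compound 1, and that gap is a 68-fold lower number from compound 1 to compound 3 (1.83 log units; beyond the scatter), a large step. The remaining measured step, a 26-fold lower number from compound 1 to compound 2 (1.41 log units; beyond the scatter), is also large, so both replacements of the cyclohexylamino group of compound 1 have brought the number far down.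

Compound 4, `CC(C(=O)NCc1ccc(C(F)(F)F)nc1N1CCC(C(F)(F)F)CC1)c1ccc(NS(C)(=O)=O)c(F)c1`, differs from compound 3 in one place: a group of 10 heavy atoms (6 carbon, 1 nitrogen, 3 fluorine; one six-membered non-aromatic ring with 1 hetero atom) in place of a group of 6 heavy atoms (5 carbon, 1 nitrogen; one six-membered non-aromatic ring with 1 hetero atom), on an aromatic carbon. The measured steps that bear on this change are the two that swap the group on the same aromatic carbon, a 68-fold lower number from compound 1 to compound 3 (1.83 log units; beyond the scatter) and a 2.7-fold lower number from compound 2 to compound 3 (0.43 log units; beyond the scatter); the first is large, the second modest. For the measured compounds named here, neither involves a trifluoromethyl group on that ring, and no measured pair tests that addition directly. Since compound 3 already carries the ring that produced the lowest number, the expectation in this assay is a step of modest size at most, with the number for compound 4 expected slightly higher than for compound 3 but within reach of the scatter, a 1.7-fold higher number from compound 3 to compound 4 (0.22 log units; within the scatter). The estimate for compound 4 is therefore 0.5 nM, with a range from 0.15 nM to 2 nM.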

Compound 4, inhibition constant: 0.6 nM
The estimate for compound 4 lay 1.2-fold (0.08 log units) below the measured number; the range from low to high includes it.
By their numbers in this assay, from the lowest: compounds 3, 4 and 2 (each within the scatter of the next, the first and the last beyond it); then compound 1.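

In this assay the 4-(trifluoromethyl)piperidin-1-yl group on this aromatic carbon cannot be told apart from either of the two lower-number groups, since a 2.0-fold higher number from compound 3 to compound 4 (0.30 log units; within the scatter) and a 1.3-fold lower number from compound 2 to compound 4 (0.12 log units; within the scatter) both lie within the scatter. With a 34-fold lower number from compound 1 to compound 4 (1.53 log units; beyond the scatter) as a large step, this is the third replacement of cyclohexylamino that brings the number far down, and it shows that this place takes a group of 10 heavy atoms and that the double bond of compound 3 is not needed for a number in this range. No measurement available here explains these steps.

Compound 4 differs from compound 3 both in the double bond and in the trifluoromethyl group, so the plain piperidine would be needed to separate the two, and a piperidine carrying a hydroxyl group or a carboxylic acid in place of the trifluoromethyl would show how far the ring accepts other substituents. Compound 1 is the only one shown with a hydrogen on the nitrogen attached to the aromatic ring, and no pair here separates that hydrogen from the change of ring.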